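The source may report more compounds than this note shows. Statements on the series, on what has been measured and on what is new or still open speak of the compounds shown alone.

Measured so far:
compound 1, `CCN(CC)c1cc2[nH]c(C3CCCCC3)nc2cc1NC(=O)c1cnccn1`, in an ADME assay on Vero cells (Chlorocebus sabaeus) for cytotoxicity, read by resazurin assay, with a stated time of 3 days; a lower number here means a stronger inhibitor, a higher number a weaker inhibitor: > 100 ug/mL
compound 2, `CN(C)c1cc2[nH]c(C3CCCCC3)nc2cc1NC(=O)c1ccc(Br)cc1`, in this assay: > 100 ug/mL
compound 3, `CCN(CC)c1cc2[nH]c(C3CCCCC3)nc2cc1NC(=O)c1ccc(N(C)C)cc1`, in this assay: "not determined" (no result reported)

Compound 1 reaches only a limit of this assay, > 100 ug/mL, and not a number. Compound 2 likewise sits at a limit, > 100 ug/mL, rather than at a measured value. For compound 3 no result was reported. Compound 2 therefore stands at the edge of what this assay reports, alongside one further limit and one entry without a number, so that no ordering among the three can be drawn; the common ground is the limit of > 100 ug/mL in this assay, at which 2 of the 3 values shown sit.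

The step to compound 4, `COc1ccc(C(=O)Nc2cc3nc(C4CCCCC4)[nH]c3cc2N(C)C)cc1`, is a single change on the amide side of the shared core: methoxy in place of bromo on an aromatic carbon. For the measured compounds named here, no step between two measured compounds exists in this assay that would show what such a change does. With compound 2 at a limit and compound 1 at the same limit, the expectation for compound 4 is no step beyond the scatter, most likely again a limit. Compound 4 is expected at 100 ug/mL, with a range from 50 ug/mL to 200 ug/mL, which means an expected step of a number no higher from compound 2 to compound 4 (the limit leaves the size open).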

Compound 4, half-maximal inhibitory concentration: > 100 ug/mL
Compound 4 gave a limit, no number (the forecaster's own chance of this, stated with the estimate: 80%); the middle value sits exactly at the limit.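

In this assay compound 4 gives > 100 ug/mL as a limit and not a number. For the compounds shown here, compound 2 also stands at a limit, so no step from bromo to methoxy can be read between compound 2 and compound 4. The compounds shown leave open where any of them would fall as an actual number in this assay and whether a change on the amide side shifts it.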